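The source may hold more compounds than are shown below. What is called first, only, known or untested is meant among the compounds shown, and "the series" means these compounds.

Measured so far in a functional assay on HeLa cells (Homo sapiens) for antiproliferative activity, read by MTT assay, with a stated time of 72 h; on this read-out lower numbers stand for stronger inhibition and higher numbers for weaker inhibition:
- compound 1 `CCC/C=C/C(=O)Nc1cccc(Oc2nc(Nc3cccc(OC)c3)nc3c2CSCC3)c1`: 33800 nM
- compound 2 `C=CC(=O)Nc1cccc(Oc2nc(Nc3ccc(OC)nc3)nc3c2CSCC3)c1`: 26300 nM

Going by the values given here, only two numbers are available, and they lie within the usual scatter of each other. Compound 2, at 26300 nM, therefore stands level with compound 1 and cannot be ranked against it.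

Compound 3 `CCC/C=C/C(=O)Nc1cccc(Oc2nc(Nc3ccc(OC)nc3)nc3c2CSCC3)c1` keeps the rest of compound 2 but carries pent-1-en-1-yl in place of vinyl on a carbonyl carbon whose other neighbour is an amide-type nitrogen: pent-1-en-1-yl in place of vinyl on a carbonyl carbon.

Among the compounds with values here, no two measured compounds differ in one place only, so the data hold no direct measure of this change. The nearest evidence is compound 1, which also carries pent-1-en-1-yl and gives 33800 nM. That value offers no sign that this group goes with a number far from that of compound 2, so no shift beyond the scatter is expected in this assay. The estimate for a 1.1-fold higher number from compound 2 to compound 3 (0.06 log units; within the scatter) is therefore a small step. Compound 3 is expected at about 30000 nM, with an estimated range of 14000 nM to 60000 nM.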

Compound 3, half-maximal inhibitory concentration: 15300 nM
Compound 3: the middle estimate sits 2.0-fold (0.29 log units) above what was measured, and the stated range covers the measured number.
By their numbers in this assay, from the lowest: compounds 3, 2 and 1 (each within the scatter of the next, the first and the last beyond it).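

In this assay, the data now hold a direct comparison at the carbonyl carbon whose other neighbour is an amide-type nitrogen: pent-1-en-1-yl in place of vinyl gives a 1.7-fold lower number from compound 2 to compound 3 (0.24 log units; within the scatter), so the longer chain is tolerated and compound 2 and compound 3 stand level on this read-out. The second comparison concerns a different place, where 6-methoxypyridin-3-yl in place of 3-methoxyphenyl on a nitrogen on an aromatic ring gives a 2.2-fold lower number from compound 1 to compound 3 (0.34 log units; beyond the scatter), a modest step and the only one here to pass beyond the usual scatter. Nothing in the available data explains either step.

The compounds shown leave open whether the change from 3-methoxyphenyl to 6-methoxypyridin-3-yl would give a step of similar size with vinyl, rather than pent-1-en-1-yl, on the carbonyl carbon. They also leave open how a fully saturated chain such as propyl, or a chain ending in a dimethylamino group, would read at that same carbonyl carbon.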